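Indole in Place of Aminopyrimidine at the Carbonyl

The compounds below may be only part of what the source reports. "The series", "measured", "known", "first", "only" and "open" are said of these compounds alone.

Measured compounds:
compound 1, `COc1ccc(-c2cc3ccccc3nc2/C=C/C(=O)c2ccc(OC)cc2OC)cc1`: 3210 nM
compound 2, `COc1ccc(-c2cc3ccccc3nc2/C=C/C(=O)c2cnc(N)nc2C)cc1`: > 10000 nM (a limit)

In a functional assay on MDA-MB-231 cells (Homo sapiens) for antiproliferative activity, read by XTT assay, with a stated time of 72 h (a higher number here means a weaker inhibitor, a lower number a stronger inhibitor), compound 1 gives 3210 nM. For compound 2 this assay reports only a limit, > 10000 nM, so compound 2 sits at the weak end of the two numbers shown, with no exact value. Among the measured compounds shown here, the single measured step, an at least 3.1-fold higher number from compound 1 to compound 2 (0.49 log units; beyond the scatter), rests on that limit, (the limit of > 10000 nM in this assay, at which 1 of the 2 values shown sits).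

Compound 3, `COc1ccc(-c2cc3ccccc3nc2/C=C/C(=O)c2c[nH]c3ccccc23)cc1`, differs from compound 2 by 1H-indol-3-yl in place of 2-amino-4-methylpyrimidin-5-yl on a carbonyl carbon. For the measured compounds named here, the one measured step bears on it only indirectly: it shows that replacing the 2,4-dimethoxyphenyl with the 2-amino-4-methylpyrimidin-5-yl lost activity, and compound 3 now removes that same pyrimidine. Compound 3 is therefore expected to move back toward compound 1, a step estimated as an at least 2.8-fold lower number from compound 2 to compound 3 (0.45 log units; beyond the scatter). Compound 3 is expected to give about 3500 nM in this assay, with a range from 1000 nM to 12000 nM.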

Compound 3, half-maximal inhibitory concentration: > 10000 nM
Compound 3: no number, only a limit; the forecaster's own chance of this, stated with the estimate: 25%; middle value at least 2.8-fold (0.45 log units) away from the limit.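

At this place on the carbonyl carbon, 1H-indol-3-yl does not recover the activity seen with 2,4-dimethoxyphenyl in this assay, the change being an at least 3.1-fold higher number from compound 1 to compound 3 (0.49 log units; beyond the scatter). The weak result is therefore no longer confined to 2-amino-4-methylpyrimidin-5-yl: a second group, with a five-membered aromatic ring and a six-membered aromatic ring of carbon only, reaches the same end of the range, and the reading is bounded by the assay: the limit of > 10000 nM in this assay, at which 2 of the 3 values shown sit. The step between compound 2 and compound 3 cannot be read, as both values are limits.

Going by these compounds, how far compound 2 and compound 3 lie beyond that limit remains open. Also open, on these data alone, is whether an unsubstituted phenyl or a pyridine on the carbonyl carbon would give a number near that of compound 1.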